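Working notes: 3,4-difluorobenzyl to 2,5-difluorobenzyl

A few compounds are considered here, and "the series" means these few. Any claim that something is new, unique, unknown or untested is made for them only; others in the source may bear on it.

Measured so far in a functional assay on Bel-7402 cells (Homo sapiens) for antiproliferative activity, read by MTT assay, with a stated time of 72 h (on this read-out higher numbers stand for weaker inhibition and lower numbers for stronger inhibition), as follows.
- compound 1 `C=C1C(=O)O[C@H]2[C@H]1CC/C(COC(=O)Cn1cc(F)c(=O)n(Cc3ccc(Br)cc3)c1=O)=C\CC[C@@]1(C)O[C@@H]21` at 2670 nM
- compound 2 `C=C1C(=O)O[C@H]2[C@H]1CC/C(COC(=O)Cn1cc(F)c(=O)n(Cc3ccc(C(F)(F)F)cc3)c1=O)=C\CC[C@@]1(C)O[C@@H]21` at 2250 nM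
- compound 3 `C=C1C(=O)O[C@H]2[C@H]1CC/C(COC(=O)Cn1cc(F)c(=O)n(Cc3ccc(F)c(F)c3)c1=O)=C\CC[C@@]1(C)O[C@@H]21` at 2700 nM

Compound 3 (2700 nM) sits level with the other two, given a 1.0-fold higher number from compound 1 to compound 3 (0.00 log units; within the scatter) and a 1.2-fold higher number from compound 2 to compound 3 (0.08 log units; within the scatter) with both within the scatter. Compound 4 `C=C1C(=O)O[C@H]2[C@H]1CC/C(COC(=O)Cn1cc(F)c(=O)n(Cc3cc(F)ccc3F)c1=O)=C\CC[C@@]1(C)O[C@@H]21` keeps the same atoms, joined differently (2,5-difluorophenyl in place of 3,4-difluorophenyl on a saturated chain carbon bound to an aromatic nitrogen). The nearest evidence is those same two steps, each of which replaced the aryl group at this place. Within the data shown here, no measured pair moves fluorines around this ring, so the read-across is indirect. No step beyond the scatter is expected in this assay for this change. The estimate means an expected 1.1-fold lower number from compound 3 to compound 4 (0.03 log units; within the scatter) at its centre. Compound 4 is estimated at 2500 nM with an expected range of 1200 nM to 5200 nM around it.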

Compound 4, half-maximal inhibitory concentration: 3060 nM
Compound 4: the middle estimate sits 1.2-fold (0.09 log units) below what was measured; the range from low to high includes it.
By their numbers in this assay, from the lowest: compounds 2, 1, 3 and 4 (each within the scatter of the next).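

In this assay, moving the two fluorines from 3,4-difluorobenzyl to 2,5-difluorobenzyl, with the atoms unchanged, stays within the scatter (a 1.1-fold higher number from compound 3 to compound 4 (0.05 log units; within the scatter)). The steps to the other two aryl groups are also within the scatter (a 1.4-fold higher number from compound 2 to compound 4 (0.13 log units; within the scatter); a 1.1-fold higher number from compound 1 to compound 4 (0.06 log units; within the scatter)), so none of the four aryl groups at this place on a saturated chain carbon bound to an aromatic nitrogen is separated from another here. No supporting measurement speaks to the reason for this flat result.

The compounds shown leave open whether an amine or a carboxylic acid on the aryl ring, or a longer chain in place of the benzyl link, would produce a step beyond the scatter.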